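Swapping methoxy for (tert-butoxycarbonyl)amino on the aromatic ring

A few compounds are considered here, and "the series" means these few. Any claim that something is new, unique, unknown or untested is made for them only; others in the source may bear on it.

- Compound 1 `CC(C)(C)c1ccc(NC(=O)CCc2cccc3c2B(O)OC3)cc1` gives 55000 nM
- Compound 2 `COc1ccc(NC(=O)CCc2cccc3c2B(O)OC3)cc1` gives > 100000 nM

In an ADME assay on WI-38 cells (Homo sapiens) for cytotoxicity, read by MTT assay, with a stated time of 72 h (on this read-out higher numbers stand for weaker inhibition and lower numbers for stronger inhibition), compound 2 gives > 100000 nM which is only a limit of the assay and not a number. Compound 3 `CC(C)(C)OC(=O)Nc1ccc(NC(=O)CCc2cccc3c2B(O)OC3)cc1` has (tert-butoxycarbonyl)amino in place of methoxy on an aromatic carbon. Going by the values given here, the one measured step that swaps this group is an at least 1.8-fold higher number from compound 1 to compound 2 (0.25 log units; that floor lies within the scatter) so no step beyond the scatter is expected in this assay in either direction. The estimated step is an at least 1.2-fold lower number from compound 2 to compound 3 (0.09 log units; that floor lies within the scatter) in size. Compound 3 is expected at 80000 nM (35000 nM to 180000 nM) in this estimate.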

Compound 3, half-maximal inhibitory concentration: > 100000 nM
Compound 3 gave a limit, no number (the forecaster's own chance of this, stated with the estimate: 45%); middle value at least 1.2-fold (0.09 log units) away from the limit.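

Going by these compounds alone, compound 3 shows that methoxy is not the only group at this position, on an aromatic carbon para to a large group, to reach the limit in this assay: compound 3 gives > 100000 nM, which is a limit and not a number. Replacing tert-butyl with (tert-butoxycarbonyl)amino gives an at least 1.8-fold higher number from compound 1 to compound 3 (0.25 log units; that floor lies within the scatter). The change from methoxy to (tert-butoxycarbonyl)amino cannot be read because both compounds sit at the same limit: the limit of > 100000 nM in this assay, at which 2 of the 3 values shown sit.

From the compounds shown here alone, the effect of an amine or a carboxylic acid at this position remains open. So does whether either would give a number rather than a limit.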